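Urea aryl swap from compound 2 to compound 3

The compounds below may be only part of what the source reports. "The series", "measured", "known", "first", "only" and "open" are said of these compounds alone.

Two ureas bearing 3-cyanophenyl on an amide-type nitrogen have been measured in a functional assay on thoracic aorta (Rattus norvegicus) for inhibition; on this read-out higher numbers stand for an effect only at larger amounts of compound and lower numbers for an effect already at smaller amounts. Compound 1 `CC1(C)CC(NC(=O)Nc2cccc(C#N)c2)c2cc(NS(C)(=O)=O)ccc2O1` gives 9300 nM in this assay, and compound 2 `CCS(=O)(=O)Nc1ccc2c(c1)C(NC(=O)Nc1cccc(C#N)c1)CC(C)(C)O2` gives 9500 nM. Going by the values given here, the single step between them, a 1.0-fold higher number from compound 1 to compound 2 (0.01 log units; within the scatter), is the methyl in place of hydrogen on a saturated chain carbon bound to a sulfonyl sulfur. Of the two numbers available, compound 2 holds the higher one, yet its gap to compound 1 is within the scatter, so the two compounds cannot be ordered.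

Compound 3 `CCS(=O)(=O)Nc1ccc2c(c1)C(NC(=O)Nc1ccc(Cl)cc1)CC(C)(C)O2` is the next compound for this assay. It differs from compound 2 by 4-chlorophenyl in place of 3-cyanophenyl on an amide-type nitrogen. Among the compounds with values here, no measured step touches this part of the molecule: the one step known, a 1.0-fold higher number from compound 1 to compound 2 (0.01 log units; within the scatter), sits on the saturated chain carbon bound to a sulfonyl sulfur and says nothing about the group on the amide-type nitrogen. Within the data shown here, with no precedent, no shift beyond the scatter is assumed in either direction, and the estimated step is no change at the digits printed from compound 2 to compound 3 (within the scatter). Compound 3 is therefore expected to give 9500 nM in this assay, in the range 3000 nM to 30000 nM.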

Compound 3, half-maximal effective concentration: > 10000 nM
Compound 3: a limit, no number (the forecaster's own chance of this, stated with the estimate: 10%); at least 1.0-fold (0.02 log units) between middle value and limit.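

In this assay compound 3 gives > 10000 nM, which is a limit of the assay and not a number. This is the first change shown on the amide-type nitrogen, and the step, an at least 1.0-fold higher number from compound 2 to compound 3 (0.02 log units; that floor lies within the scatter), has a floor that does not separate 4-chlorophenyl from 3-cyanophenyl: the swap may leave the read-out where it stands or raise it by an amount the data do not give. The position has therefore gained a bound on one side only, with no number for the 4-chlorophenyl urea, and one compound of the series now rests at that limit: the limit of > 10000 nM in this assay, at which 1 of the 3 values shown sits.

Open is whether any group on the amide-type nitrogen gives an effect at smaller amounts of compound, as only 3-cyanophenyl and 4-chlorophenyl are shown there, and an unsubstituted phenyl, a pyridine ring or a cyclohexyl group would each give a further reading at this place. Also open is how far the sulfonyl side tolerates change, with a longer chain or a phenyl ring on the sulfonyl sulfur lying outside the compounds shown.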